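A Fourth Benzyl Variant Expected to Stay at the Limit

The source may hold more compounds than are shown below. What is called first, only, known or untested is meant among the compounds shown, and "the series" means these compounds.

Three compounds share one core and differ only in the group on a saturated chain carbon bound to an aromatic nitrogen: compound 1 `O=c1ccoc2cc(OCc3cn(Cc4ccc([N+](=O)[O-])cc4)nn3)ccc12`, compound 2 `O=c1ccoc2cc(OCc3cn(Cc4ccccc4Br)nn3)ccc12` and compound 3 `O=c1ccoc2cc(OCc3cn(Cc4ccc(Cl)cc4Cl)nn3)ccc12`. In an ADME assay on L02 cells (Homo sapiens) for cytotoxicity, read by MTT assay, with a stated time of 48 h (a lower number here means a stronger inhibitor, a higher number a weaker inhibitor), compound 1 gives > 300000 nM, which is a limit of the assay and not a number. In this assay compound 2 gives > 300000 nM, again a limit rather than a number. In this assay compound 3 gives > 300000 nM, also a limit. Compound 2 therefore stands exactly where its two companions stand, as summed up by the limit of > 300000 nM in this assay, at which 3 of the 3 values shown sit. The steps a step that the two limits leave unreadable from compound 1 to compound 2, a step that the two limits leave unreadable from compound 1 to compound 3 and a step that the two limits leave unreadable from compound 2 to compound 3 are consequently unreadable in size and direction.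

Compound 4 `O=c1ccoc2cc(OCc3cn(Cc4ccc(Cl)cc4)nn3)ccc12` has not yet been measured. Its difference from compound 2 is 4-chlorophenyl in place of 2-bromophenyl on a saturated chain carbon bound to an aromatic nitrogen. All three measured steps bear on this kind of change, yet none of them can be read, because every value sits at the same limit (the limit of > 300000 nM in this assay, at which 3 of the 3 values shown sit). No step beyond the scatter is expected in this assay in either direction. The expected value for compound 4 is estimated at 300000 nM, within a range of 100000 nM to 1000000 nM, most probably reported once more as a limit. The step expected from compound 2 to compound 4 is a number no higher from compound 2 to compound 4 (the limit leaves the size open), which is none beyond the scatter.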

Compound 4, half-maximal inhibitory concentration: > 300000 nM
Compound 4 ended at the assay's limit (the forecaster's own chance of this, stated with the estimate: 90%); the middle value lies on the limit itself.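

Compound 4 joins compound 1, compound 2 and compound 3 at a limit rather than a number in this assay, so the steps from compound 4's three companions to it cannot be read in size or direction: the limit of > 300000 nM in this assay, at which 4 of the 4 values shown sit. The compounds shown leave open whether any group at this place brings a readable value in this assay.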